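This account rests on a few compounds, and the source may have more. Where it says the series, first, only, none or still open, it means among the compounds named here.

Compound 1 (`COc1cc(OC)c(OC)cc1/C=C/C(=O)c1ccc(Cl)cc1`) is one of two compounds with a measured value in a functional assay, read by Griess assay, with a stated time of 2.5 h (a lower number here means a stronger inhibitor, a higher number a weaker inhibitor), where compound 1 gives 2.01 ug/mL as its half-maximal inhibitory concentration. Compound 2 (`COc1cc(OC)c(OC)cc1/C=C/C(=O)c1cc(OC(C)=O)ccc1OC(C)=O`) gives 2.37 ug/mL in the same read-out. The two numbers lie within the usual scatter of each other, so compound 1 cannot be separated from compound 2 on these data.

Compound 3 (`COc1ccc(C(=O)/C=C/c2cc(OC)c(OC)cc2OC)cc1`) has not yet been measured. It departs from compound 1 in a single place: methoxy in place of chloro on an aromatic carbon. This is methoxy in place of chloro on an aromatic carbon, para to a large group, and the rest of the core of compound 1 stays the same.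

Going by the values given here, no measured step isolates this change, so the data offer no direct guide to its size. Among the compounds with values here, with only two close values in hand, no step beyond the scatter is expected in this assay in either direction. For compound 3 the expected value is 2.5 ug/mL with an estimated range of 1.1 ug/mL to 5.5 ug/mL in this read-out. The estimate corresponds to an expected 1.2-fold higher number from compound 1 to compound 3 (0.09 log units; within the scatter) that remains within the scatter.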

Compound 3, half-maximal inhibitory concentration: 2.07 ug/mL
The estimate for compound 3 lay 1.2-fold (0.08 log units) above the measured number; the range from low to high includes it.
By their numbers in this assay, from the lowest: compounds 1, 3 and 2 (each within the scatter of the next).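

In this assay, going by these compounds alone, the exchange of chloro for methoxy on an aromatic carbon, para to a large group, gives a 1.0-fold higher number from compound 1 to compound 3 (0.01 log units; within the scatter) and is the first step measured at this position. The 4-chlorophenyl and 4-methoxyphenyl forms of the shared core therefore cannot be told apart in this read-out, even though the entering group brings one more heavy atom and one hydrogen-bond acceptor that the leaving chloro does not have. At this position, then, these two groups are interchangeable as far as this read-out can show, but no supporting measurement is available to explain that result.

The position has so far been probed with only these two groups, so a single step within the scatter does not show whether the same flat result would hold for an amine, a carboxylic acid or a longer chain such as butoxy on that aromatic carbon. On these data alone, it also remains open whether methoxy and chloro would still read alike in this assay if the other parts of the core of compound 1 were changed.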